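Swapping amino for isopropyl on a shared core

This account rests on a few compounds, and the source may have more. Where it says the series, first, only, none or still open, it means among the compounds named here.

Of the compounds shown here, three built on one shared core have been tested in a toxicity assay on CCRF-CEM cells (Homo sapiens) for cytotoxicity; on this read-out lower numbers stand for higher toxicity in this test and higher numbers for lower toxicity in this test. Compound 1 `Oc1cccc2c1nc(-c1c(F)cccc1F)n2Cc1c(F)cccc1F` carries a hydroxy group on the aromatic carbon; in this assay compound 1 gives > 100 uM, which is a limit of the test rather than a number. Compound 2 `Nc1cccc2c1nc(-c1c(F)cccc1F)n2Cc1c(F)cccc1F` carries an amino group in that place, and in this assay compound 2 gives 26.3 uM. Compound 3 `CN(C)c1cccc2c1nc(-c1c(F)cccc1F)n2Cc1c(F)cccc1F` carries a dimethylamino group; in this assay compound 3 gives > 100 uM, again a limit. Among the three, compound 2 holds the only actual number, while the other two values sit at the limit of > 100 uM in this assay, at which 2 of the 3 values shown sit. The measured steps read an at least 3.8-fold lower number from compound 1 to compound 2 (0.58 log units; beyond the scatter) and an at least 3.8-fold higher number from compound 2 to compound 3 (0.58 log units; beyond the scatter), whereas the change from hydroxy to dimethylamino is a step that the two limits leave unreadable from compound 1 to compound 3.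

Compound 4 `CC(C)c1cccc2c1nc(-c1c(F)cccc1F)n2Cc1c(F)cccc1F` has not yet been measured. It differs from compound 2 by isopropyl in place of amino on an aromatic carbon. Every group other than amino tried so far has pushed the value beyond the scatter and out of the readable window, so a rise of similar or larger size is expected here as well, quite possibly ending in a limit rather than a number. The step expected is a 3.0-fold higher number from compound 2 to compound 4 (0.48 log units; beyond the scatter). Compound 4 is therefore estimated at 80 uM, with a range from 25 uM to 250 uM.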

Compound 4, half-maximal toxic concentration: 27 uM
For compound 4 the middle estimate is 3.0-fold (0.47 log units) above the measured one, within the range that was stated.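

In this assay, swapping amino for isopropyl on this aromatic carbon leaves the read-out in place, with a 1.0-fold higher number from compound 2 to compound 4 (0.01 log units; within the scatter), even though isopropyl is made of carbon only and has no hydrogen-bond donor or acceptor, so the donor and acceptor of amino are not needed for a value in this range. Within the data shown here, compound 4 also stands apart from the two compounds at the limit, with an at least 3.7-fold lower number from compound 3 to compound 4 (0.56 log units; beyond the scatter) and with an at least 3.7-fold lower number from compound 1 to compound 4 (0.56 log units; beyond the scatter), which means that amino is no longer the only group at this place to give a readable number. Both of these sizes are minimum sizes only, as each starts from a limit of the test and not from a number: the limit of > 100 uM in this assay, at which 2 of the 4 values shown sit.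

The four groups fall into no simple order, and the compounds shown do not tell what separates amino and isopropyl from hydroxy and dimethylamino. A methyl group, a methoxy group, a chlorine atom or a longer chain such as n-propyl on the same aromatic carbon would show whether a readable number here is common or confined to these two groups.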